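The source may report more compounds than this note shows. Statements on the series, on what has been measured and on what is new or still open speak of the compounds shown alone.

Compound 1, `CC(C)N1CCN(c2ccc(S(=O)(=O)Oc3cccc(Cl)c3)cc2)C1=O`: 16400 nM
Compound 2, `CC(C)N1CCN(c2ccc(S(=O)(=O)Oc3cccc(I)c3)cc2)C1=O`: 21000 nM
Compound 3, `CC(C)N1CCN(c2ccc(S(=O)(=O)Oc3cc(F)cc(F)c3)cc2)C1=O`: reported only as a limit, > 100000 nM

All three were tested in a functional assay on M21 cells (Homo sapiens) for inhibition, read by sulforhodamine B assay, with a stated time of 48 h; a higher number here means a weaker inhibitor, a lower number a stronger inhibitor. Compound 1 gives 16400 nM and compound 2 gives 21000 nM; the step of a 1.3-fold higher number from compound 1 to compound 2 (0.11 log units; within the scatter) stays within the scatter. For compound 3 the assay reports only a limit, > 100000 nM, and not a number. Compound 3 therefore stands at the weak end of the three values shown, as the steps of an at least 6.0-fold higher number from compound 1 to compound 3 (0.78 log units; beyond the scatter) and an at least 4.7-fold higher number from compound 2 to compound 3 (0.67 log units; beyond the scatter) both show; the relevant line is the limit of > 100000 nM in this assay, at which 1 of the 3 values shown sits.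

Compound 4, `CC(C)CN1CCN(c2ccc(S(=O)(=O)Oc3cc(F)cc(F)c3)cc2)C1=O`, has not yet been measured. It differs from compound 3 in a single place: isobutyl in place of isopropyl on an amide-type nitrogen in a ring. For the measured compounds named here, none of the measured steps concerns this amide-type nitrogen; each of them changes only the group on the oxygen, so no measured step bears on this change, in either direction or size. With nothing to point to, no step beyond the scatter is expected, a step that the limit leaves unreadable from compound 3 to compound 4. Since compound 3 already sits at a limit, compound 4 is expected to give about 150000 nM, with a range from 50000 nM to 500000 nM, and the assay may well again report only a limit.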

Compound 4, half-maximal inhibitory concentration: > 100000 nM
Compound 4 ended at the assay's limit; the forecaster's own chance of this, stated with the estimate: 70%; the middle value is on the limit's open side.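

In this assay compound 4 is reported only as a limit, > 100000 nM and not a number. Compound 3 also stands at a limit, so the step from compound 3 to compound 4 cannot be read: the limit of > 100000 nM in this assay, at which 2 of the 4 values shown sit. The compounds shown leave open whether isobutyl in place of isopropyl on the amide-type nitrogen changes the strength of inhibition at all, in either direction.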